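Swapping a Small Ring for a Bromophenyl Group

The source may hold more compounds than are shown below. What is called first, only, known or untested is meant among the compounds shown, and "the series" means these compounds.

Compound 1, `C[Si](C)(C)c1cn(C[C@H](O)[C@H]2OC(=O)C(OCc3ccccc3)=C2OCc2ccccc2)nn1`, gives 52600 nM in a functional assay on CFPAC-1 cells (Homo sapiens) for antiproliferative activity, read by MTT assay, with a stated time of 72 h; on this read-out higher numbers stand for weaker inhibition and lower numbers for stronger inhibition.
Compound 2, `COc1ccc(-c2cn(C[C@H](O)[C@H]3OC(=O)C(OCc4ccccc4)=C3OCc3ccccc3)nn2)cc1`, gives 26000 nM in this assay.
Compound 3, `O=C1O[C@H]([C@@H](O)Cn2cc(C3CC3)nn2)C(OCc2ccccc2)=C1OCc1ccccc1`, gives 47700 nM in this assay.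

All three compounds share the same core and differ only in the group attached to the five-membered aromatic ring with 3 nitrogen. Compound 3 sits second highest of the three numbers, but neither neighbour is clearly separated from it: a 1.1-fold lower number from compound 1 to compound 3 (0.04 log units; within the scatter), and a 1.8-fold higher number from compound 2 to compound 3 (0.26 log units; within the scatter). For the measured compounds named here, every compound so far is a weak inhibitor in this assay.

Compound 4, `O=C1O[C@H]([C@@H](O)Cn2cc(-c3ccc(Br)cc3)nn2)C(OCc2ccccc2)=C1OCc1ccccc1`, is the next step from compound 3. (4-bromophenyl in place of cyclopropyl on an aromatic carbon). Two earlier steps speak to this change. Putting a six-membered aromatic ring in place of a group without a ring gave a 2.0-fold lower number from compound 1 to compound 2 (0.31 log units; beyond the scatter). Replacing a six-membered aromatic ring with cyclopropyl gave a 1.8-fold higher number from compound 2 to compound 3 (0.26 log units; within the scatter). Compound 4 carries a six-membered aromatic ring again, so a modest move toward a lower number is expected, about a 1.7-fold lower number from compound 3 to compound 4 (0.23 log units; within the scatter). For compound 4 in this assay the estimated value is 28000 nM, with a likely range from 12000 nM to 60000 nM.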

Compound 4, half-maximal inhibitory concentration: 5830 nM
Estimate against measurement, compound 4: 4.8-fold (0.68 log units) above, and the stated range ends above it.
By their numbers in this assay, from the lowest: compound 4; then compounds 2, 3 and 1 (each within the scatter of the next, the first and the last beyond it).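

Compound 2 and compound 3 lie within the scatter of each other, so a six-membered aromatic ring on this carbon of the five-membered ring is not enough on its own; what that ring carries also counts, as bromo in place of methoxy gives a 4.5-fold lower number from compound 2 to compound 4 (0.65 log units; beyond the scatter) in this assay. The whole change from cyclopropyl to 4-bromophenyl gives an 8.2-fold lower number from compound 3 to compound 4 (0.91 log units; beyond the scatter), and the change from the silicon-bearing group gives a 9.0-fold lower number from compound 1 to compound 4 (0.96 log units; beyond the scatter), which makes compound 4 the strongest of the four, with each of its steps beyond the scatter. Nothing available here accounts for the difference between bromo and methoxy on this ring.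

The compounds shown leave open whether another group in place of bromo, such as chloro, an amine or a carboxylic acid, would keep or extend this gain, and whether the bromine must stay where it sits in 4-bromophenyl. As far as these compounds go, it also remains open whether the same gain would hold if the shared core were changed.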